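Replacing 2-vinylphenyl with thiophen-2-yl on the shared core

The source may report more compounds than this note shows. Statements on the series, on what has been measured and on what is new or still open speak of the compounds shown alone.

- compound 1 `COC1=C(C)C(=O)/C(=C(O)/C=C/c2ccc(Br)cc2)C(=O)C1(C)C` gives 1.7 ug/mL
- compound 2 `COC1=C(C)C(=O)/C(=C(O)/C=C/c2ccc(O)cc2)C(=O)C1(C)C` gives 3.8 ug/mL
- compound 3 `C=Cc1ccccc1/C=C/C(O)=C1/C(=O)C(C)=C(OC)C(C)(C)C1=O` gives 1.9 ug/mL

All three values come from a functional assay on KB cells (Homo sapiens) for cytotoxicity; on this read-out lower numbers stand for an effect already at smaller amounts and higher numbers for an effect only at larger amounts of compound. At 1.9 ug/mL, compound 3 lies within the scatter of both other compounds: the steps are a 1.1-fold higher number from compound 1 to compound 3 (0.05 log units; within the scatter) and a 2.0-fold lower number from compound 2 to compound 3 (0.30 log units; within the scatter). Going by the values given here, only one measured step goes beyond the scatter, and it is modest: a 2.2-fold higher number from compound 1 to compound 2 (0.35 log units; beyond the scatter).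

The next compound, compound 4 `COC1=C(C)C(=O)/C(=C(O)/C=C/c2cccs2)C(=O)C1(C)C`, carries thiophen-2-yl in place of 2-vinylphenyl on a double-bonded chain carbon bound to a double-bonded chain carbon. Among the compounds with values here, no measured compound carries thiophen-2-yl, so the evidence is indirect. The two steps that change the group at this place, a 1.1-fold higher number from compound 1 to compound 3 (0.05 log units; within the scatter) and a 2.0-fold lower number from compound 2 to compound 3 (0.30 log units; within the scatter), both stay within the scatter, although the groups exchanged in them differ. On that basis, no step beyond the scatter is expected in this assay, and no direction can be favoured with confidence. The estimated step is a 1.3-fold higher number from compound 3 to compound 4 (0.10 log units; within the scatter). For compound 4 the expected value is 2.4 ug/mL, with an estimated range from 1.1 ug/mL to 5.2 ug/mL.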

Compound 4, concentration for half-maximal effect: 5.5 ug/mL
For compound 4 the middle estimate is 2.3-fold (0.36 log units) below the measured one; the whole stated range lies below it.
By their numbers in this assay, from the lowest: compounds 1, 3, 2 and 4 (each within the scatter of the next, the first and the last beyond it).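

Going by these compounds alone, with thiophen-2-yl on a double-bonded chain carbon bound to a double-bonded chain carbon, a change of group at this place reaches beyond the scatter in this assay for the first time: there is a 2.9-fold higher number from compound 3 to compound 4 (0.46 log units; beyond the scatter) and also a 3.2-fold higher number from compound 1 to compound 4 (0.51 log units; beyond the scatter) and both are modest, while the earlier exchanges here stayed within the scatter. Even so, the change does not set thiophen-2-yl apart from every phenyl group, as replacing 4-hydroxyphenyl gives a 1.4-fold higher number from compound 2 to compound 4 (0.16 log units; within the scatter) and leaves compound 4 within the scatter of compound 2. Nothing given here accounts for these steps.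

The compounds shown leave open whether the higher number of compound 4 goes with the sulfur atom, with the five-membered aromatic ring or with the absence of any substituent on the ring, and a furan-2-yl or an unsubstituted phenyl group at this place would help to separate these. They also leave open how a pyridine ring, a saturated cyclohexyl group or a phenyl ring bearing an amine would read at the same place.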